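Two Inactive Spiro Compounds and a Trimethylphenyl Variant

The source may hold more compounds than are shown below. What is called first, only, known or untested is meant among the compounds shown, and "the series" means these compounds.

Compound 1 `COc1ccc(-n2nncc2CN2C(=O)C3(C(C#N)=C(N)Oc4c(N)cc5nc6ccccc6nc5c43)c3ccccc32)cc1` and compound 2 `CCc1cccc(CC)c1-n1nncc1CN1C(=O)C2(C(C#N)=C(N)Oc3c(N)cc4nc5ccccc5nc4c32)c2ccccc21` share one core and differ only in the group on an aromatic nitrogen. In a functional assay on A549 cells (Homo sapiens) for antiproliferative activity, read by MTT assay, with a stated time of 48 h (a lower number here means a stronger inhibitor, a higher number a weaker inhibitor), compound 1 gives > 50000 nM, which is a limit of the assay rather than a number. In this assay compound 2 likewise gives > 50000 nM, again a limit. The step that the two limits leave unreadable from compound 1 to compound 2 is therefore unreadable, and the limit of > 50000 nM in this assay, at which 2 of the 2 values shown sit, shows that both values sit at that limit. Compound 3 `Cc1cc(C)c(-n2nncc2CN2C(=O)C3(C(C#N)=C(N)Oc4c(N)cc5nc6ccccc6nc5c43)c3ccccc32)c(C)c1` carries 2,4,6-trimethylphenyl in place of 2,6-diethylphenyl on an aromatic nitrogen. No readable step bears on this change, so compound 3 is expected to remain near the limit, giving an estimated 80000 nM within 30000 nM to 300000 nM, an expected step that the limit leaves unreadable from compound 2 to compound 3.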

Compound 3, half-maximal inhibitory concentration: 12700 nM
For compound 3 the middle estimate is 6.3-fold (0.80 log units) above the measured one; measured number below the stated range.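

Replacing 2,6-diethylphenyl with 2,4,6-trimethylphenyl on the aromatic nitrogen gives an at least 3.9-fold lower number from compound 2 to compound 3 (0.59 log units; beyond the scatter). Replacing 4-methoxyphenyl with the same group gives an at least 3.9-fold lower number from compound 1 to compound 3 (0.59 log units; beyond the scatter). This position can therefore change the result in this assay, and compound 3 alone has a readable value, while the other two remain at a limit: the limit of > 50000 nM in this assay, at which 2 of the 3 values shown sit.

On these data alone, the true size of both steps remains unknown, as each starts from a limit. As far as these compounds go, how a phenyl ring carrying an amine or a carboxylic acid would behave at this position also remains open.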